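Bromo for carboxy on the pendant aryl ring

This account rests on a few compounds, and the source may have more. Where it says the series, first, only, none or still open, it means among the compounds named here.

Compound 1 `Cn1cncc1C(O)(c1ccc(C#N)cc1)c1cc2cc([N+](=O)[O-])cc(-c3ccccc3)c2o1`: 1480 nM in a functional assay on QG-56 cells (Homo sapiens) for antiproliferative activity; on this read-out higher numbers stand for weaker inhibition and lower numbers for stronger inhibition.
Compound 2 `Cn1cncc1C(O)(c1ccc([N+](=O)[O-])cc1)c1cc2cc([N+](=O)[O-])cc(-c3ccccc3)c2o1`: 547 nM.
Compound 3 `Cn1cncc1C(O)(c1ccc(C(=O)O)cc1)c1cc2cc([N+](=O)[O-])cc(-c3ccccc3)c2o1`: > 10000 nM, which is a limit of the assay and not a number.

Compound 3 is the only entry of the three without a number; it sits at the limit of > 10000 nM in this assay, at which 1 of the 3 values shown sits. The steps leading to it are an at least 6.7-fold higher number from compound 1 to compound 3 (0.82 log units; beyond the scatter) and an at least 18-fold higher number from compound 2 to compound 3 (1.26 log units; beyond the scatter), both beyond the scatter, whereas a 2.7-fold lower number from compound 1 to compound 2 (0.43 log units; beyond the scatter) is modest. Compound 4 `Cn1cncc1C(O)(c1ccc(Br)cc1)c1cc2cc([N+](=O)[O-])cc(-c3ccccc3)c2o1` differs from compound 3 by bromo in place of carboxy on an aromatic carbon. The two measured steps into compound 3 point the same way: the carboxy-bearing compound gives the weakest number seen, while compound 1 and compound 2, which lack carboxy there, lie well lower. Within the data shown here, no measured step carries bromo itself, so the expectation rests on the removal of carboxy and on the range spanned by compound 1 and compound 2. Compound 4 is therefore expected to move back toward that range, a step estimated as an at least 6.6-fold lower number from compound 3 to compound 4 (0.82 log units; beyond the scatter). The estimate for compound 4 in this assay is 1500 nM, expected to fall between 500 nM and 5000 nM.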

Compound 4, half-maximal inhibitory concentration: 1480 nM
Compound 4: middle estimate off by 1.0-fold (0.01 log units), on the high side; measured number inside the range.
By their numbers in this assay, from the lowest: compound 2; then compounds 1 and 4 (each within the scatter of the next). At a limit, above all of these: compound 3.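

In this assay, the change from 4-carboxyphenyl to 4-bromophenyl gives an at least 6.7-fold lower number from compound 3 to compound 4 (0.82 log units; beyond the scatter), so a group with no hydrogen-bond donor or acceptor, and no other atom than bromine, is enough at this place on the pendant ring to leave the carboxy compound behind. Bromo and cyano cannot be told apart on this read-out, no change at the digits printed from compound 1 to compound 4 (within the scatter), while nitro keeps its lead over bromo, a 2.7-fold higher number from compound 2 to compound 4 (0.43 log units; beyond the scatter), so compound 2 still carries the lowest number of the series and the three non-carboxy groups do not all read alike. Compound 3 remains a limit of the assay and not a number, which leaves every step into or out of it a bound only: the limit of > 10000 nM in this assay, at which 1 of the 4 values shown sits.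

The compounds shown leave open whether the loss belongs to carboxy alone or also appears with an amine, a hydroxy group, a methyl ester or a primary amide on the same aromatic carbon. They also leave open where the unsubstituted phenyl compound would fall, and whether any group, such as methoxy or trifluoromethyl, would bring the number below that of compound 2.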